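The source may report more compounds than this note shows. Statements on the series, on what has been measured and on what is new or still open speak of the compounds shown alone.

Measured compounds in the series so far:
- compound 1 `O=c1nc(NCC2CCCCC2)oc2c([N+](=O)[O-])cc(C(F)(F)F)cc12`: 29.7 ug/mL
- compound 2 `O=c1nc(NC2CCCCC2)oc2c([N+](=O)[O-])cc(C(F)(F)F)cc12`: 5.39 ug/mL
- compound 3 `O=c1nc(Nc2ccccc2)oc2c([N+](=O)[O-])cc(C(F)(F)F)cc12`: 37.9 ug/mL

All three share one core and differ only in the group on a nitrogen on an aromatic ring. In an ADME assay on Vero cells (Chlorocebus sabaeus) for cytotoxicity, read by MTT assay, with a stated time of 48 h (on this read-out lower numbers stand for stronger inhibition and higher numbers for weaker inhibition), compound 3 gives the highest number of the three; its gap to compound 1 is within the scatter, while the step of a 7.0-fold higher number from compound 2 to compound 3 (0.85 log units; beyond the scatter) is beyond it. The step of a 5.5-fold lower number from compound 1 to compound 2 (0.74 log units; beyond the scatter) shows that taking away a methylene between the ring and the nitrogen gives a lower number; the step of a 1.3-fold higher number from compound 1 to compound 3 (0.11 log units; within the scatter) shows that a saturated ring on a methylene and an aromatic ring set directly on the nitrogen give the same number within the scatter.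

Compound 4 `O=c1nc(NCc2ccccc2)oc2c([N+](=O)[O-])cc(C(F)(F)F)cc12` carries the change (benzyl in place of phenyl on a nitrogen on an aromatic ring). Inserting a methylene is the reverse of the only step that moved the number, so at most a modest rise is expected, with a result within the scatter of compound 3 the likelier outcome. Compound 4 is therefore expected to give about 45 ug/mL in this assay, ranging from 20 ug/mL to 100 ug/mL, a step of a 1.2-fold higher number from compound 3 to compound 4 (0.07 log units; within the scatter).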

Compound 4, half-maximal inhibitory concentration: 25.4 ug/mL
For compound 4 the middle estimate is 1.8-fold (0.25 log units) above the measured one; measured number inside the range.
By their numbers in this assay, from the lowest: compound 2; then compounds 4, 1 and 3 (each within the scatter of the next).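

In this assay adding a methylene to the phenyl group gives no step beyond the scatter: a 1.5-fold lower number from compound 3 to compound 4 (0.17 log units; within the scatter) stands against the step beyond the scatter seen for the same methylene in the saturated pair, so the effect of this methylene is not shared by the two ring types. On the methylene, an aromatic ring and a saturated ring are not told apart, with a 1.2-fold lower number from compound 1 to compound 4 (0.07 log units; within the scatter) also within the scatter. With a 4.7-fold higher number from compound 2 to compound 4 (0.67 log units; beyond the scatter) beyond it, compound 2 stays the only one set apart, its steps to compound 1, compound 3 and compound 4 all beyond the scatter. Nothing available accounts for this result.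

Open, from the compounds shown here alone, is whether the lower number belongs to cyclohexyl alone or also to other saturated rings set directly on the nitrogen, such as cyclopentyl or cycloheptyl. Also open, going by these compounds, is how a longer chain, such as phenethyl or cyclohexylethyl, reads at this place.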